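The compounds below may be only part of what the source reports. "The series", "measured", "known", "first", "only" and "open" are said of these compounds alone.

The account concerns a small set of compounds examined in an assay on HEK293 cells for agonist activity at transient receptor potential cation channel subfamily M member 8 (Homo sapiens), read by fluorescence and calcium flux, with a stated time of 15 min; on this read-out lower numbers stand for an effect already at smaller amounts and higher numbers for an effect only at larger amounts of compound. Compound 1 `Cc1ccc(OCC(=O)N(Cc2cccs2)c2cnn(C)c2)cc1` gives 63000 nM in this assay, the highest of the two numbers recorded so far. Compound 2 `COc1ccc2oc(C(=O)N(Cc3cccs3)c3ccn[nH]3)cc2c1` gives 1.1 nM in this assay, a far lower number. The two compounds differ in more than one place, so their pair says nothing about any single change. Compound 3 `Cc1ccc(OCC(=O)N(Cc2cccs2)c2ccn[nH]2)cc1` has not yet been measured in this assay. It differs from compound 1 in one place: 1H-pyrazol-5-yl in place of 1-methyl-1H-pyrazol-4-yl on an amide-type nitrogen. Within the data shown here, no measured pair separated by exactly this change exists, so the size of the step cannot be read from the numbers at hand. Among the measured compounds shown here, still, with compound 1 standing at 63000 nM and the only other number far lower, a step toward a lower number in this assay is expected to be the more likely direction, and a large one is plausible. The estimate for compound 3 is 2000 nM, with a range from 150 nM to 25000 nM. The step from compound 1 to compound 3 that this estimate implies is a 32-fold lower number from compound 1 to compound 3 (1.50 log units; beyond the scatter), expected rather than measured.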

Compound 3, half-maximal effective concentration: 0.2 nM
The estimate for compound 3 lay 10000-fold (4.00 log units) above the measured number; the whole stated range lies above it.
By their numbers in this assay, from the lowest: compound 3; then compound 2; then compound 1.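

In this assay, placing 1H-pyrazol-5-yl in place of 1-methyl-1H-pyrazol-4-yl on the amide-type nitrogen gives a 320000-fold lower number from compound 1 to compound 3 (5.50 log units; beyond the scatter). The earlier pair differed in more than one place and could not be tied to any single change, whereas this pair shows that this one position, with the rest of the structure held constant, can by itself decide between a very high and a very low number. The exchange is also a compact one in terms of what is counted: the group that leaves has 6 heavy atoms, 0 hydrogen-bond donors and 2 hydrogen-bond acceptors, and the group that enters has 5 heavy atoms, 1 hydrogen-bond donor and 1 hydrogen-bond acceptor.

Whether a 1H-pyrazol-4-yl or a 1-methyl-1H-pyrazol-5-yl group on the same nitrogen would fall closer to compound 1 or to compound 3 remains open, so the compounds shown do not separate the loss of the methyl group from the change in how the ring is attached. Nothing given here accounts for the size of the step.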